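The source may report more compounds than this note shows. Statements on the series, on what has been measured and on what is new or still open speak of the compounds shown alone.

Measured compounds in a functional assay on PC-3 cells (Homo sapiens) for cytotoxicity, read by MTT assay, with a stated time of 72 h; on this read-out higher numbers stand for weaker inhibition and lower numbers for stronger inhibition: compound 1 `FC(F)(F)c1ccc(CSc2nc(Nc3ccccc3)c3ccccc3n2)cc1` gives 20000 nM; compound 2 `FC(F)(F)c1ccc(CSc2nc(Nc3cccc(C(F)(F)F)c3)c3ccccc3n2)cc1` gives 12900 nM.

Compound 2 holds the lower of the two numbers, but the step of a 1.6-fold lower number from compound 1 to compound 2 (0.19 log units; within the scatter) is within the scatter, so no order between compound 1 and compound 2 is established.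

Compound 3 `O=[N+]([O-])c1ccc(Nc2nc(SCc3ccc(C(F)(F)F)cc3)nc3ccccc23)cc1` differs from compound 2 by 4-nitrophenyl in place of 3-(trifluoromethyl)phenyl on a nitrogen on an aromatic ring. Within the data shown here, only the step of a 1.6-fold lower number from compound 1 to compound 2 (0.19 log units; within the scatter) bears on this, and it was within the scatter; no measured change on this nitrogen has moved this assay beyond the scatter. A step of a 1.0-fold higher number from compound 2 to compound 3 (0.00 log units; within the scatter) is therefore expected, that is none beyond the scatter. Compound 3 is estimated at 13000 nM, range 5000 nM to 40000 nM.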

Compound 3, half-maximal inhibitory concentration: 7900 nM
The estimate for compound 3 lay 1.6-fold (0.22 log units) above the measured number; measured number inside the range.
By their numbers in this assay, from the lowest: compounds 3, 2 and 1 (each within the scatter of the next, the first and the last beyond it).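

Among these compounds, the step of a 2.5-fold lower number from compound 1 to compound 3 (0.40 log units; beyond the scatter) in this assay is the first change on this nitrogen's aryl group to pass beyond the scatter, though only modestly, with nitro in place of hydrogen on an aromatic carbon. The exchange of 3-(trifluoromethyl)phenyl for 4-nitrophenyl remains unresolved, since the step of a 1.6-fold lower number from compound 2 to compound 3 (0.21 log units; within the scatter) separates neither group. No supporting data explain the nitro step.
As far as these compounds go, whether an amine or a carboxylic acid in place of nitro would give a comparable step remains open. So does whether any change here can move this modest cytotoxicity further.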